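The source may report more compounds than this note shows. Statements on the series, on what has been measured and on what is new or still open speak of the compounds shown alone.

Compound 1 `O=C(Nc1ccccc1)c1cc(Br)cc(Br)c1` was tested in an assay on isolated protein for inhibition of thiosulfate sulfurtransferase (Homo sapiens), with a stated time of 60 min, in the absence of a further agent; on this read-out higher numbers stand for weaker inhibition and lower numbers for stronger inhibition. In this assay compound 1 gives > 100000 nM, which is a limit of the assay and not a number. Compound 2 `O=C(Nc1ccccc1)c1cc(Br)cc(Br)c1O` carries a hydroxy group that compound 1 lacks. In this assay compound 2 gives > 100000 nM, again a limit rather than a number. The change from compound 2 to compound 1, (hydrogen in place of hydroxy on an aromatic carbon), thus leaves a step that the two limits leave unreadable from compound 2 to compound 1; both values sit at the limit of > 100000 nM in this assay, at which 3 of the 3 values shown sit. Compound 3 `O=C(Nc1ccc(Sc2nc3ccccc3s2)c(Cl)c1)c1ccccc1O` rests on a different core; the difference between the two cores is not broken down here. In this assay compound 3 gives > 100000 nM, once more a limit of the assay. Compound 4 `O=C(Nc1ccc(Sc2nc3ccccc3s2)c(Cl)c1)c1ccccc1` has not yet been measured in this assay. It differs from compound 3 by hydrogen in place of hydroxy on an aromatic carbon, the same kind of change as that from compound 2 to compound 1, though not the same: here the place is ortho to a large group, whereas in compound 2 it is ortho to a bromo group (1 heavy atom), ortho to a group of 9 heavy atoms and para to a bromo group (1 heavy atom). The earlier step that the two limits leave unreadable from compound 2 to compound 1 offers no readable size. Because compound 3 sits at the limit of > 100000 nM in this assay, at which 3 of the 3 values shown sit, the step is expected to be a number no higher from compound 3 to compound 4 (the limit leaves the size open). Compound 4 is therefore expected to give 100000 nM, most likely reported again only as a limit.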

Compound 4, half-maximal inhibitory concentration: > 100000 nM
Compound 4 gave a limit, no number; the forecaster's own chance of this, stated with the estimate: 80%; the middle value lies on the limit itself.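

The step from compound 3 to compound 4 cannot be read, and no size can be given for it, as both compounds rest on a limit of the assay: the limit of > 100000 nM in this assay, at which 4 of the 4 values shown sit.

The compounds shown leave open whether hydrogen in place of hydroxy changes anything in this assay on either core, and which structure would give a readable number there.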